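From 1,3-benzothiazol-6-yl to 3-phenyl-1H-pyrazol-5-yl on the carbonyl

A few compounds are considered here, and "the series" means these few. Any claim that something is new, unique, unknown or untested is made for them only; others in the source may bear on it.

In an ADME assay (liver) for metabolic stability, with Liver microsome (Rattus norvegicus) as the target, using microsomes (a lower number here means slower removal, a higher number faster removal of the compound), compound 2 (`CN(C(=O)c1ccc2ncsc2c1)c1ccc(OCc2ccc3ccccc3c2)cc1`) gives 48.3 mL/min/kg as its clearance, and compound 1 (`CN(C(=O)c1ccc2ncsc2c1)c1ccc(OCB2C=Cc3ccccc3N2)cc1`) gives 73.3 mL/min/kg on the same scale. Among the compounds with values here, the only measured step is a 1.5-fold lower number from compound 1 to compound 2 (0.18 log units; within the scatter) and it lies within the scatter, so compound 2 cannot be separated from compound 1 on these numbers.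

Compound 3 (`CN(C(=O)c1cc(-c2ccccc2)n[nH]1)c1ccc(OCc2ccc3ccccc3c2)cc1`) differs from compound 2 as follows: 3-phenyl-1H-pyrazol-5-yl in place of 1,3-benzothiazol-6-yl on a carbonyl carbon. Within the data shown here, the measured step sits on a saturated chain carbon bound to an oxygen on an aromatic ring, not on the carbonyl carbon, so no measured step covers this change and none points to a direction. No shift beyond the scatter is therefore expected, and the expected step is a 1.0-fold higher number from compound 2 to compound 3 (0.02 log units; within the scatter) in this assay. For compound 3 the estimated clearance is 50 mL/min/kg with an expected range from 24 mL/min/kg to 100 mL/min/kg as the likely span.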

Compound 3, clearance: 6.83 mL/min/kg
Compound 3: middle estimate off by 7.3-fold (0.86 log units), on the high side; the whole stated range lies above it.
By their numbers in this assay, from the lowest: compound 3; then compounds 2 and 1 (each within the scatter of the next).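

In this assay, the carbonyl carbon bound to the amide-type nitrogen proves to be a sensitive place: 3-phenyl-1H-pyrazol-5-yl in place of 1,3-benzothiazol-6-yl gives a 7.1-fold lower number from compound 2 to compound 3 (0.85 log units; beyond the scatter), whereas the change on the saturated chain carbon bound to an oxygen on an aromatic ring stayed within the scatter, at a 1.5-fold lower number from compound 1 to compound 2 (0.18 log units; within the scatter). The entering group has 11 heavy atoms against 9 and 1 hydrogen-bond donor against 0, so the larger group here comes with the lower clearance, in this single pair. No measurement at hand accounts for the step.

As far as these compounds go, the change alters several features at once, so it remains open whether the step follows the pyrazole, its hydrogen-bearing nitrogen or the phenyl. Also open, from the compounds shown here alone, is how a methyl group or a carboxylic acid in place of that phenyl would read.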